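A Larger Ring Group at the Same Aromatic Carbon

This account rests on a few compounds, and the source may have more. Where it says the series, first, only, none or still open, it means among the compounds named here.

Compound 1 `CCCCOC(=O)NS(=O)(=O)c1ccc(CCC)cc1-c1ccc(Cn2cnc3ccccc32)cc1` gives 29 nM in an assay on membranes from HEK293 cells for displacement of a labelled ligand from Type-2 angiotensin II receptor (Homo sapiens), read by radioligand binding; a higher number here means a weaker inhibitor, a lower number a stronger inhibitor.
Compound 2 `CCCCOC(=O)NS(=O)(=O)c1ccc(CCC)cc1-c1ccc(Cn2c(CCC)nc3ccccc32)cc1` gives 14 nM in this assay.

Within the data shown here, compound 2 has the lower of the two numbers; the step of a 2.1-fold lower number from compound 1 to compound 2 (0.32 log units; beyond the scatter) is the only measured change so far. Compound 3 `CCCCOC(=O)NS(=O)(=O)c1ccc(CCC)cc1-c1ccc(Cn2c(C3CCCC3)nc3ccccc32)cc1` continues at the same position with cyclopentyl in place of propyl on an aromatic carbon. Among the measured compounds shown here, no measured step tests this exact change; the only related step, a 2.1-fold lower number from compound 1 to compound 2 (0.32 log units; beyond the scatter), showed that filling this position helped by a modest amount. Compound 3 is therefore expected to stay close to compound 2, with perhaps a small further gain, a 1.4-fold lower number from compound 2 to compound 3 (0.15 log units; within the scatter). The estimate for compound 3 in this assay is 10 nM, within 4 nM to 30 nM.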

Compound 3, inhibition constant: 35 nM
For compound 3 the middle estimate is 3.5-fold (0.54 log units) below the measured one; measured number above the stated range.
By their numbers in this assay, from the lowest: compound 2; then compounds 1 and 3 (each within the scatter of the next).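

Filling this position does not keep helping as the group grows: cyclopentyl in place of propyl brings a 2.5-fold higher number from compound 2 to compound 3 (0.40 log units; beyond the scatter) in this assay and cancels the gain that propyl gave. Cyclopentyl in place of hydrogen brings a 1.2-fold higher number from compound 1 to compound 3 (0.08 log units; within the scatter) and so leaves no real gain over the unfilled position. Nothing measured here says why the ring group does worse than the chain.

Open, as far as these compounds go, is how a smaller ring such as cyclopropyl, or a longer chain such as butyl, would fare on this aromatic carbon.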